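A few compounds are considered here, and "the series" means these few. Any claim that something is new, unique, unknown or untested is made for them only; others in the source may bear on it.

The study concerns four compounds sharing one core, a chlorinated aryl ether on a fused heterocycle carrying an aryl ring with an amine-bearing side chain on its oxygen. Compound 1 `CN1CCC(Oc2ccc(-c3nc4ccc(Oc5ccc(Cl)cc5)cc4o3)cc2)CC1` carries a 1-methylpiperidin-4-yl group there, and in an assay on isolated protein for inhibition of advanced glycosylation end product-specific receptor (Homo sapiens), read by FRET, with stated times of 30 min and 1 h, tested at 4 uM (on this read-out lower numbers stand for less inhibition and higher numbers for more inhibition at the one concentration tested (going by the name of the read-out)), compound 1 gives 19.5%. Among the measured compounds shown here, compound 2 `CN(C)CCCOc1ccc(-c2nc3ccc(Oc4ccc(Cl)cc4)cc3o2)cc1` carries a 3-(dimethylamino)propyl chain instead, and in this assay compound 2 gives 4.9%; the only step measured between neighbours, a number 14.6 percentage points lower from compound 1 to compound 2 (beyond the scatter), shows that opening the ring into a chain lowered the read-out. Compound 3 `Clc1ccc(Oc2ccc3nc(-c4ccc(OCCCN5CCCC5)cc4)oc3c2)cc1` carries a 3-(pyrrolidin-1-yl)propyl chain, and in this assay compound 3 is reported as "not active" (no number reported), so no single number places it; on the evidence shown it stands at or below the level of compound 2.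

Compound 4 `Clc1ccc(Oc2ccc3nc(-c4ccc(OCCCN5CCNCC5)cc4)oc3c2)cc1` is the unmeasured neighbour of compound 3, differing by piperazin-1-yl in place of pyrrolidin-1-yl on a saturated chain carbon, three bonds along the chain from an oxygen on an aromatic ring. For the measured compounds named here, no measured step bears directly on exchanging one saturated amine ring for another at the end of this chain; the one step known, a number 14.6 percentage points lower from compound 1 to compound 2 (beyond the scatter), concerns a different change and only shows that the number in this region went lower. Compound 4 is therefore expected to stay low in this assay, with an estimated value of 5%, ranging from 0% to 20%.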

Compound 4, a percentage reported as inhibition, at one concentration (the size of the read-out at that concentration, not a potency): 42.7%
Estimate against measurement, compound 4: 37.7 percentage points below; the whole stated range lies below it.
By their numbers in this assay, from the lowest: compound 2; then compound 1; then compound 4.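

In this assay the end of the chain proves to be a place where the read-out can rise, not only fall: with the propyl chain kept, piperazin-1-yl in place of dimethylamino gives a number 37.8 percentage points higher from compound 2 to compound 4 (beyond the scatter). The earlier compounds shown here showed only a lower number on going from the ring of compound 1 to an open chain, yet the 3-(piperazin-1-yl)propyl group in place of 1-methylpiperidin-4-yl gives a number 23.2 percentage points higher from compound 1 to compound 4 (beyond the scatter), so compound 2 and compound 3 carry that chain type without the higher number, and compound 4 goes against any rule that an open chain lowers it. Compound 3 is reported as "not active" (no number reported), so the exchange of pyrrolidin-1-yl for piperazin-1-yl cannot be read as a step, although only compound 4 of the two has a number.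

Nothing shown accounts for the higher number of compound 4. From the compounds shown here alone, it stays open whether the same chain ending in piperidin-1-yl, morpholin-4-yl or 4-methylpiperazin-1-yl would hold the number of compound 4, and whether piperazin-1-yl on a shorter or longer chain would do so.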